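Working notes on a four-compound set

A few compounds are considered here, and "the series" means these few. Any claim that something is new, unique, unknown or untested is made for them only; others in the source may bear on it.

Three compounds of this set carry a number in a functional assay on the whole organism with Rattus norvegicus as the target; a lower number here means that less compound is needed, a higher number that more compound is needed for the effect. Compound 1 `Nc1nc2ccc(SC(F)(F)F)cc2s1` gives 8 mg/kg. Compound 2 `Nc1nc2ccc(OCC(F)(F)F)cc2s1` gives 6.5 mg/kg. Compound 3 `CCCCn1c(=N)sc2cc(OC(F)(F)F)ccc21` gives 10 mg/kg. Of these three numbers that of compound 3 is the largest; its smaller gap is to compound 1 and its larger gap to compound 2, and both gaps lie within the usual scatter of repeated measurements, so the three compounds cannot be separated on the numbers seen so far. Within the data shown here, no two measured compounds differ in a single place, so no measured step is available to set the size of the next one.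

Compound 4 `CSCn1c(=N)sc2cc(OC(F)(F)F)ccc21` is the unmeasured member and follows from compound 3 by one change: methylsulfanyl in place of propyl on a saturated chain carbon bound to an aromatic nitrogen. The group that leaves is propyl and the group that enters is methylsulfanyl, both on a saturated chain carbon bound to an aromatic nitrogen. With no measured step of this kind in the set, the expectation for this assay is a step of small size, in no settled direction, and not beyond the scatter. On that basis compound 4 is estimated at 10 mg/kg, with a range from 5 mg/kg to 20 mg/kg. The step this estimate means, no change at the digits printed from compound 3 to compound 4 (within the scatter), is expected to remain within the scatter.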

Compound 4, dose for half-maximal effect: 3 mg/kg
The estimate for compound 4 lay 3.3-fold (0.52 log units) above the measured number; measured number outside the range, below it.
By their numbers in this assay, from the lowest: compound 4; then compounds 2, 1 and 3 (each within the scatter of the next).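

In this assay the place on a saturated chain carbon bound to an aromatic nitrogen responds to its substituent: methylsulfanyl in place of propyl gives a step (a 3.3-fold lower number from compound 3 to compound 4 (0.52 log units; beyond the scatter)) that lies beyond the scatter. Among these compounds, the earlier compounds could not show this, as none of them differs from another in a single place, and their numbers could not be separated; this is the first reading of both the size and the direction of a change at this place, with less compound needed once methylsulfanyl enters, or, cut one bond further out, once butyl becomes (methylsulfanyl)methyl. Nothing at hand bears on the reason for this step.

From the compounds shown here alone, it stays open whether the step belongs to the sulfur atom or to the change in heavy atoms, since the group that enters differs from propyl in both, and methoxy in the same place would separate the two. Going by these compounds, it is also open how far the step extends along this place, which a longer chain carrying sulfur or an amine could test, and whether it would hold with a group other than the trifluoromethoxy shared by compound 3 and compound 4.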